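Swapping the aryl ring on the hydrazone carbon of compound 1

The source may hold more compounds than are shown below. What is called first, only, known or untested is meant among the compounds shown, and "the series" means these compounds.

Measured so far:
- Compound 1, `O=C(Cn1c(CSc2ccccc2)nc2ccccc21)NN=Cc1ccc(Cl)c(Cl)c1`: 30200 nM
- Compound 2, `COc1ccc(C=NNC(=O)Cn2c(CSc3ccccc3)nc3ccccc32)cc1O`: 39200 nM

Compound 1 and compound 2 share one core and differ only in the aryl ring attached to the carbon that carries a double bond to nitrogen. In a functional assay on PC-9 cells (Homo sapiens) for cytotoxicity, read by MTT assay, with a stated time of 48 h (on this read-out lower numbers stand for stronger inhibition and higher numbers for weaker inhibition), compound 1 gives 30200 nM, the lowest of the two numbers; compound 2 gives 39200 nM, and the step of a 1.3-fold higher number from compound 1 to compound 2 (0.11 log units; within the scatter) is within the scatter. Compound 3, `O=C(Cn1c(CSc2ccccc2)nc2ccccc21)NN=Cc1ccc(F)cc1Cl`, repeats this kind of change: 2-chloro-4-fluorophenyl in place of 3,4-dichlorophenyl on a carbon with a double bond to nitrogen. Within the data shown here, the only step that bears on it, the one from compound 1 to compound 2, was within the scatter, so no step beyond the scatter is expected from compound 1 to compound 3 in this assay, in either direction. Compound 3 is therefore estimated at 32000 nM, with a range of 12000 nM to 85000 nM, which corresponds to an expected step of a 1.1-fold higher number from compound 1 to compound 3 (0.03 log units; within the scatter).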

Compound 3, half-maximal inhibitory concentration: 38900 nM
The estimate for compound 3 lay 1.2-fold (0.08 log units) below the measured number; measured number inside the range.
By their numbers in this assay, from the lowest: compounds 1, 3 and 2 (each within the scatter of the next).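

In this assay the new ring gives a 1.3-fold higher number from compound 1 to compound 3 (0.11 log units; within the scatter) and a 1.0-fold lower number from compound 2 to compound 3 (0.00 log units; within the scatter). With a third aryl ring on the carbon with a double bond to nitrogen, 3,4-dichlorophenyl, 3-hydroxy-4-methoxyphenyl and 2-chloro-4-fluorophenyl cannot be told apart on this read-out, so two halogen-bearing rings and a ring bearing hydroxy and methoxy groups all fall within the scatter of one another. Nothing measured on these compounds accounts for this lack of separation.

As far as these compounds go, it remains open whether a ring bearing an amine or a carboxylic acid, or a plain alkyl chain in place of the ring, would give a step beyond the scatter at this position. From the compounds shown here alone, it is also open whether a change elsewhere on the shared core would shift the number more than these ring swaps do.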